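A few compounds are considered here, and "the series" means these few. Any claim that something is new, unique, unknown or untested is made for them only; others in the source may bear on it.

Compound 3 `Cc1nc(S(C)(=O)=O)ccc1Oc1ncnc(OC2CCN(C(=O)SC3CCC3)CC2)c1F` gives 81% in a functional assay on isolated protein for inhibition of Glucose-dependent insulinotropic receptor (Rattus norvegicus), read by HTRF and cAMP accumulation (a lower number here means a smaller maximal response, a higher number a larger maximal response), and stands second highest among the three measured compounds. Its nearest neighbour is compound 2 `Cc1nc(S(C)(=O)=O)ccc1Oc1ncnc(OC2CCN(C(=O)O[C@@H](C)C(F)(F)F)CC2)c1F`, which gives 80%; the step of a number 1 percentage points higher from compound 2 to compound 3 (within the scatter) stays within the scatter. Furthest off is compound 1 `Cc1nc(S(C)(=O)=O)ccc1Oc1ncnc(OC2CCN(C(=O)OC(C)(C)C#N)CC2)c1F`, which gives 97%; the step of a number 16 percentage points lower from compound 1 to compound 3 (beyond the scatter) lies beyond the scatter, as does a number 17 percentage points lower from compound 1 to compound 2 (beyond the scatter). All three measured compounds share the same core and differ only in the group on the carbonyl carbon of the ring amide.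

Compound 4 `CCc1cnc(C(=O)N2CCC(Oc3ncnc(Oc4ccc(S(C)(=O)=O)nc4C)c3F)CC2)nc1` is not yet measured. Relative to compound 3 the change is 5-ethylpyrimidin-2-yl in place of cyclobutylsulfanyl on a carbonyl carbon. Every measured step bears on it in that each also exchanges the group on this carbonyl carbon, yet none of them brings in an aromatic ring, so none is a close match. The two exchanges among the three measured groups moved the maximal response by a modest amount at most, and one moved it not at all. Compound 4 is therefore expected to give a maximal response in this assay close to that of compound 3, with the step of a number 4 percentage points higher from compound 3 to compound 4 (within the scatter) estimated to fall within or only modestly beyond the scatter. The estimate for compound 4 is 85%, with a range from 70% to 100%.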

Compound 4, largest response reached (reported as efficacy), in percent of the reference or control that the assay uses: 80%
For compound 4 the middle estimate is 5 percentage points above the measured one; the range from low to high includes it.
By their numbers in this assay, from the lowest: compounds 2, 4 and 3 (each within the scatter of the next); then compound 1.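

Within the data shown here, on the carbonyl carbon whose other neighbour is the amide-type nitrogen in a ring, 5-ethylpyrimidin-2-yl puts a six-membered aromatic ring at this place for the first time, and in this assay the exchange for cyclobutylsulfanyl gives a number 1 percentage points lower from compound 3 to compound 4 (within the scatter), while the exchange for 1-(trifluoromethyl)ethoxy gives no change at the digits printed from compound 2 to compound 4 (within the scatter). The maximal response therefore does not separate these three groups, although they differ in the atom bonded to the carbonyl carbon and in ring type, and only the exchange for 1-cyano-1-methylethoxy, a number 17 percentage points lower from compound 1 to compound 4 (beyond the scatter), separates compound 4 from another compound, so compound 1 now stands apart from three different groups rather than two. No measurement at hand accounts for this separation of compound 1 from the other three compounds.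

On these data alone, it remains open whether the nitrile or the two methyl groups within 1-cyano-1-methylethoxy carry the higher response of compound 1. Also open, as far as these compounds go, is whether an amine, a carboxylic acid or a longer chain in place of the ethyl of 5-ethylpyrimidin-2-yl would keep the response of compound 4 in this assay.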